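The source may hold more compounds than are shown below. What is called first, only, known or untested is meant among the compounds shown, and "the series" means these compounds.

Compound 1 `COC(=O)c1cccc(NC(=O)COc2ccc(C)cc2)c1` gives > 40000 nM in an assay for inhibition of malate dehydrogenase, cytoplasmic (Homo sapiens), with a stated time of 30 min; on this read-out lower numbers stand for stronger inhibition and higher numbers for weaker inhibition.
Compound 2 `CN1CCN(c2ccc(NC(=O)COc3ccc(C(C)(C)CC(C)(C)C)cc3)cc2)CC1` gives 3000 nM in this assay.

Compound 1 carries a methyl on its phenoxy ring and a methyl ester on the aniline ring. Its result in this assay is not a number but a limit of the assay, (the limit of > 40000 nM in this assay, at which 1 of the 2 values shown sits), so nothing more than that is known about where compound 1 stands. For the measured compounds named here, compound 2, which differs from compound 1 in several places at once, does give a number, but with no single-point step between the two no change can be assigned to any one of those differences.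

Compound 3 `CCCCCc1ccc(OCC(=O)Nc2cccc(C(=O)OC)c2)cc1` is the direct neighbour of compound 1: the difference is butyl in place of hydrogen on a saturated chain carbon bound to an aromatic carbon. Going by the values given here, no measured step of this kind is available among the compounds here, so any expectation rests on the bare fact that compound 1 sits at the limit of this assay and that compound 2, with a larger group on the same ring, returns a measurable value. The step from compound 1 to compound 3 is expected to move toward stronger inhibition, an at least 2.0-fold lower number from compound 1 to compound 3 (0.30 log units; that floor lies within the scatter), though with wide uncertainty. Compound 3 is therefore estimated at 20000 nM, within a range from 5000 nM to 80000 nM.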

Compound 3, half-maximal inhibitory concentration: 6790 nM
Beside the measured number, compound 3's estimate is 2.9-fold (0.47 log units) above it, and the stated range covers the measured number.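

Replacing hydrogen with butyl on the saturated chain carbon bound to an aromatic carbon, which can also be read as methyl becoming pentyl, gives an at least 5.8-fold lower number from compound 1 to compound 3 (0.77 log units; beyond the scatter) in this assay. Unlike the earlier pair, this pair differs in one place only, so the change in the read-out can be tied to this single change, with the methyl ester and the rest of the core of compound 1 left as they were. The true size of the step is not known, and the printed size is only a floor, because the result for compound 1 is a limit: the limit of > 40000 nM in this assay, at which 1 of the 3 values shown sits.

The compounds shown leave open how the read-out follows chain length, as only methyl and pentyl appear at this place, so an ethyl or propyl chain, or a longer chain such as heptyl, would be needed to show whether the change is gradual or levels off. Also open, from the compounds shown here alone, is whether a pentyl chain ending in an amine or a carboxylic acid would keep this gain, and whether the gain survives when the methyl ester is replaced by a carboxylic acid.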